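Swapping Methyl for Fluorine on the Benzyl Ring

A few compounds are considered here, and "the series" means these few. Any claim that something is new, unique, unknown or untested is made for them only; others in the source may bear on it.

Compound 3 `Cc1ccc(Cn2cc(CSC(=S)N3CCN(C(=O)OCc4ccccc4)CC3)nn2)cc1` is tested in a functional assay on ECa-109 cells (Homo sapiens) for inhibition, read by MTT assay, with a stated time of 72 h (on this read-out lower numbers stand for stronger inhibition and higher numbers for weaker inhibition), where it gives 32600 nM. Among the compounds with values here, of the two numbers measured so far, this is the lower one. Its nearest neighbour is compound 2 `COc1ccc(Cn2cc(CSC(=S)N3CCN(C(=O)OCc4ccccc4)CC3)nn2)cc1`, which gives 58300 nM in this assay; the step of a 1.8-fold lower number from compound 2 to compound 3 (0.25 log units; within the scatter) is small and lies within the scatter. Compound 1 `Fc1ccc(Cn2cc(CSC(=S)N3CCNCC3)nn2)cc1` gives only a limit, > 128000 nM, in this assay. That value is the limit of > 128000 nM in this assay, at which 1 of the 3 values shown sits, rather than a measured number. Compound 1 differs from compound 4 in more than one place, so its limit alone says little about the change studied here.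

Compound 4 `O=C(OCc1ccccc1)N1CCN(C(=S)SCc2cn(Cc3ccc(F)cc3)nn2)CC1` has not yet been measured. The change from compound 3 is fluoro in place of methyl on an aromatic carbon. Within the data shown here, the only measured step at the same position, from methoxy to methyl, stayed within the scatter, so no shift beyond the scatter is expected from this swap either. Compound 4 is therefore estimated to give about 40000 nM in this assay, between 15000 nM and 130000 nM. That estimate means an expected step of a 1.2-fold higher number from compound 3 to compound 4 (0.09 log units; within the scatter).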

Compound 4, half-maximal inhibitory concentration: 32000 nM
Beside the measured number, compound 4's estimate is 1.3-fold (0.10 log units) above it; the range from low to high includes it.
By their numbers in this assay, from the lowest: compounds 4, 3 and 2 (each within the scatter of the next). At a limit, above all of these: compound 1.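

On the benzyl ring, fluoro now reads the same as methyl in this assay (a 1.0-fold lower number from compound 3 to compound 4 (0.01 log units; within the scatter)) and the same as methoxy (a 1.8-fold lower number from compound 2 to compound 4 (0.26 log units; within the scatter)), so all three groups at this place lie within the scatter of one another. Within the data shown here, the clear difference comes from elsewhere in the molecule: with the 4-fluorobenzyl group kept, benzyloxycarbonyl in place of hydrogen on the amine nitrogen in a ring gives the only step here beyond the scatter (an at least 4.0-fold lower number from compound 1 to compound 4 (0.60 log units; beyond the scatter)). The value for compound 1 is a limit and not a number: (the limit of > 128000 nM in this assay, at which 1 of the 4 values shown sits).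

On these data alone, it remains open whether a different kind of group on this aromatic carbon, such as an amine, a carboxylic acid or a longer chain, would move the number beyond the scatter. As far as these compounds go, it is also open whether another group on that nitrogen, such as acetyl, would do the same as benzyloxycarbonyl.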